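This account rests on a few compounds, and the source may have more. Where it says the series, first, only, none or still open, it means among the compounds named here.

Values so far in a functional assay on K562 cells (Homo sapiens) for antiproliferative activity, read by MTT assay, with a stated time of 48 h; on this read-out higher numbers stand for weaker inhibition of growth and lower numbers for stronger inhibition of growth
- compound 1 `CCOc1cc(NC(=O)CCCCC(=O)Nc2cc(-c3ccccc3)ccc2N)cc2c1OCC([N+](=O)[O-])=C2` gives 5270 nM
- compound 2 `CCOc1cc(NC(=O)CCCCCCC(=O)Nc2cc(-c3ccccc3)ccc2N)cc2c1OCC([N+](=O)[O-])=C2` gives 2000 nM
- compound 3 `CCOc1cc(NC(=O)CCCCCCC(=O)Nc2ccccc2N)cc2c1OCC([N+](=O)[O-])=C2` gives 3360 nM

Compound 3 lies within the scatter of both compound 1 and compound 2, so it is not separated from either. Compound 4 `CCOc1cc(NC(=O)CCCCCCC(=O)Nc2cc(-c3ccc(C)s3)ccc2N)cc2c1OCC([N+](=O)[O-])=C2` differs from compound 3 by 5-methylthiophen-2-yl in place of hydrogen on an aromatic carbon. Among the compounds with values here, the one measured step that bears on this is the exchange of phenyl for hydrogen (a 1.7-fold higher number from compound 2 to compound 3 (0.23 log units; within the scatter)), which stays within the scatter. Within the data shown here, no thiophene compound has been measured. Read in reverse, that step suggests a small move towards a lower number in this assay and nothing expected beyond the scatter. The expected move is a 1.5-fold lower number from compound 3 to compound 4 (0.18 log units; within the scatter) and remains tentative. For compound 4 the estimate is 2200 nM with an expected range of 1000 nM to 4800 nM as its bounds.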

Compound 4, concentration for 50% growth inhibition: 3110 nM
Compound 4: middle estimate off by 1.4-fold (0.15 log units), on the low side; the measured number falls inside the stated range.
By their numbers in this assay, from the lowest: compounds 2, 4, 3 and 1 (each within the scatter of the next, the first and the last beyond it).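

In this assay a second ring type, 5-methylthiophen-2-yl, at the position para to an amino group gives a 1.1-fold lower number from compound 3 to compound 4 (0.03 log units; within the scatter) and so stays within the scatter of hydrogen, as phenyl does. Its exchange for phenyl gives a 1.6-fold higher number from compound 2 to compound 4 (0.19 log units; within the scatter), so these two rings are not separated here. No available evidence explains these results.

On these data alone, whether an amine or a carboxylic acid on this ring would move the number beyond the scatter remains open. Also open, as far as these compounds go, is whether 5-methylthiophen-2-yl behaves alike on the shorter chain of compound 1.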